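Swapping fluorine for chlorine on the amide aryl group

The compounds below may be only part of what the source reports. "The series", "measured", "known", "first", "only" and "open" are said of these compounds alone.

Of the compounds shown here, two from this series have been tested in a functional assay on SK-BR-3 cells (Homo sapiens) for antiproliferative activity, read by MTT assay, with a stated time of 72 h; on this read-out higher numbers stand for weaker inhibition and lower numbers for stronger inhibition. Compound 1, with structure `Cc1cc(NCCN2CCCC2)nc2ccc(NC(=O)c3ccc(Cl)c(Cl)c3)cc12`, gives 9530 nM in this assay. Compound 2, with structure `CCN1CCN(c2cc(C)c3cc(NC(=O)c4ccc(F)c(F)c4)ccc3n2)CC1`, gives 1980 nM in this assay, the lowest of the two numbers and therefore the stronger inhibitor; the gap to compound 1 lies beyond the usual scatter. The two compounds differ in more than one place, so the two values alone cannot tell which part of the structure accounts for that gap.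

Compound 3, with structure `CCN1CCN(c2cc(C)c3cc(NC(=O)c4ccc(Cl)c(Cl)c4)ccc3n2)CC1`, has not yet been measured. It keeps the core of compound 2 and changes only the aryl group on the amide: 3,4-dichlorophenyl in place of 3,4-difluorophenyl on a carbonyl carbon. Among the measured compounds shown here, compound 1 carries the same 3,4-dichlorophenyl group, though on a different core, and its value of 9530 nM is the weaker of the two known numbers. On that basis a small step from compound 2 toward a higher number, a 1.4-fold higher number from compound 2 to compound 3 (0.15 log units; within the scatter), is expected, possibly within the scatter. Compound 3 is estimated at 2800 nM, with a range from 900 nM to 8000 nM.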

Compound 3, half-maximal inhibitory concentration: 2160 nM
For compound 3 the middle estimate is 1.3-fold (0.11 log units) above the measured one; low and high end bracket the measured number.
By their numbers in this assay, from the lowest: compounds 2 and 3 (each within the scatter of the next); then compound 1.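

On the carbonyl carbon of the amide, 3,4-dichlorophenyl in place of 3,4-difluorophenyl gives a 1.1-fold higher number from compound 2 to compound 3 (0.04 log units; within the scatter) in this assay, so this assay does not separate these two aryl groups on the core of compound 2. Compound 3 also forms a one-place pair with compound 1: with the 3,4-dichlorophenyl amide held constant, 4-ethylpiperazin-1-yl in place of (2-(pyrrolidin-1-yl)ethyl)amino on an aromatic carbon gives a 4.4-fold lower number from compound 1 to compound 3 (0.64 log units; beyond the scatter), a change that lies beyond the scatter and that earlier could not be separated from the change in the aryl group. Nothing available here explains the size of either step.

The compounds shown do not reveal whether the amide position would tolerate a phenyl group without halogens, or one carrying a methoxy group or a nitrile, as it tolerates these two dihalogenated groups. They also leave open how a morpholin-4-yl group or a 4-methylpiperazin-1-yl group on that aromatic carbon would compare with 4-ethylpiperazin-1-yl.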